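Dimethylamino for acetyl on a pyrazole-linked aryl ring

The source may report more compounds than this note shows. Statements on the series, on what has been measured and on what is new or still open speak of the compounds shown alone.

Compound 1 `COc1cc(C)cc(-c2c(-c3ccnc(-c4ccc(C(C)=O)cc4)c3)cnn2CC#N)c1` gives 5800 nM; compound 2 `Cc1cc(O)cc(-c2nn(CC#N)cc2-c2ccnc(-c3ccc(Oc4ccccc4)cc3)c2)c1` gives 2160 nM; compound 3 `COc1cc(C)cc(-c2nn(CC#N)cc2-c2ccnc(-c3ccc(N(C)C)cc3)c2)c1` gives 696 nM, all in a functional assay on EKVX cells (Homo sapiens) for inhibition, read by sulforhodamine B assay, with a stated time of 48 h; on this read-out higher numbers stand for weaker inhibition of growth and lower numbers for stronger inhibition of growth.

Compound 1 stands at the highest of the three numbers in this assay; compound 2 sits nearer to it and compound 3 furthest, both beyond the scatter. Compound 4 `COc1cc(C)cc(-c2c(-c3ccnc(-c4ccc(N(C)C)cc4)c3)cnn2CC#N)c1` differs from compound 1 by one change, (dimethylamino in place of acetyl on an aromatic carbon), dimethylamino in place of acetyl on an aromatic carbon. Going by the values given here, no measured pair shows this step directly. Compound 3, which also carries dimethylamino, shows the lowest number of the three at 696 nM, though its core is arranged differently from that of compound 1. A step downward beyond the scatter is expected, a 3.9-fold lower number from compound 1 to compound 4 (0.59 log units; beyond the scatter). Compound 4 is estimated at 1500 nM, within 500 nM to 4500 nM.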

Compound 4, concentration for 50% growth inhibition: 290 nM
Estimate against measurement, compound 4: 5.2-fold (0.71 log units) above; the whole stated range lies above it.
By their numbers in this assay, from the lowest: compound 4; then compound 3; then compound 2; then compound 1.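

In this assay, going by these compounds alone, the change from 4-acetylphenyl to 4-(dimethylamino)phenyl gives a 20-fold lower number from compound 1 to compound 4 (1.30 log units; beyond the scatter) on the shared core, the first direct reading of a single change at this position. Both groups have 3 heavy atoms and 1 hydrogen-bond acceptor, so these counts alone do not set the number here. Nothing at hand gives a reason for so large a step.

Going by these compounds, what a primary amine or a morpholine would give at this place remains open, and so does whether the same change holds on the core of compound 3.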